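A single group exchanged on a well-retained compound

The source may hold more compounds than are shown below. What is called first, only, known or untested is meant among the compounds shown, and "the series" means these compounds.

In an ADME assay on a cell-free system (plasma, Rattus norvegicus) for metabolic stability, read by LC-MS, with a stated time of 60 min, tested at 100 uM (a lower number here means that less of the compound is left, a higher number that more of the compound is left), compound 1 (`Cc1c(OCCCCOCOc2ccc(C(=O)O)cc2)ccc(C(=O)CC2CCCC2)c1O`) gives 100% and compound 2 (`COc1cc(C(=O)O)ccc1OCCCCOc1ccc(C(=O)CC(C)C)c(O)c1C`) gives 99% and these two values lie within the usual scatter of each other. Compound 3 (`Cc1c(OCCCCOc2cccc(C(=O)O)c2)ccc(C(=O)CC2CCCC2)c1O`) carries 3-carboxyphenyl in place of (4-carboxyphenoxy)methyl on an oxygen on a saturated carbon. Going by the values given here, no measured pair shows such an exchange. Compound 1 at 100% and compound 2 at 99% differ in structure yet show no gap beyond the scatter. The estimated step of a number 3 percentage points lower from compound 1 to compound 3 (within the scatter) is expected to stay within the scatter. In this assay compound 3 is expected at 97% with 88% to 103% as its estimated range.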

Compound 3, percent of the compound remaining: 99%
Beside the measured number, compound 3's estimate is 2 percentage points below it; the measured number falls inside the stated range.
By their numbers in this assay, from the lowest: compounds 2, 3 and 1 (each within the scatter of the next).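

On an oxygen on a saturated carbon, the exchange to 3-carboxyphenyl from (4-carboxyphenoxy)methyl gives the first step read at one place in this assay: a number 1 percentage points lower from compound 1 to compound 3 (within the scatter). This shows that the position tolerates this particular exchange with no change in the read-out beyond the scatter, although the two groups differ in size and in how the carboxylic acid is attached. Nothing available explains this outcome.

All the compounds shown carry a carboxylic acid, so it remains open whether a primary amide or a tetrazole in its place would stay within the scatter of these numbers. Also open, from the compounds shown here alone, is whether any exchange at this place would move the number beyond the scatter.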